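The compounds below may be only part of what the source reports. "The series", "measured", "known", "first", "only" and "open" are said of these compounds alone.

Working notes on the series, read in a functional assay on MCF7 cells (Homo sapiens) for inhibition, read by MTT assay, with a stated time of 72 h; a lower number here means a stronger inhibitor, a higher number a weaker inhibitor. Compound 1 `COc1cc(NC(C)CCCNC(=O)NNC(=O)Nc2ccc(Br)cc2)c2ncccc2c1`, carrying a 4-bromophenyl group, gives 100 nM. Compound 2 `COc1cc(NC(C)CCCNC(=O)NNC(=O)Nc2cccc(F)c2)c2ncccc2c1`, carrying a 3-fluorophenyl group on the same core and chain, gives 150 nM. The measured step is a 1.5-fold higher number from compound 1 to compound 2 (0.18 log units; within the scatter), so compound 2 stands level with compound 1 within the scatter, and no other measured value is available to place it.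

Compound 3 `COc1cc(NC(C)CCCNC(=O)NNC(=O)Nc2cccc(Cl)c2)c2ncccc2c1` differs from compound 2 in one place: chloro in place of fluoro on an aromatic carbon. This is chloro in place of fluoro on an aromatic carbon, meta to a large group. For the measured compounds named here, only one measured step bears on this change, and it is an imperfect guide, since it swaps the halogen and moves it as well. Going by the values given here, no measurement yet isolates a change of halogen at this one place. That single step stayed within the scatter, so no shift beyond the scatter is expected here, and no direction can be argued from the data. The expected step is a 1.3-fold lower number from compound 2 to compound 3 (0.10 log units; within the scatter). For compound 3 the estimated value is 120 nM, with an expected range of 50 nM to 300 nM.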

Compound 3, half-maximal inhibitory concentration: 220 nM
The estimate for compound 3 lay 1.8-fold (0.26 log units) below the measured number; the range from low to high includes it.
By their numbers in this assay, from the lowest: compounds 1, 2 and 3 (each within the scatter of the next, the first and the last beyond it).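

In this assay, for the compounds shown here, the exchange of fluoro for chloro on an aromatic carbon, meta to a large group, gives the first reading of a change of halogen alone at this place: a 1.5-fold higher number from compound 2 to compound 3 (0.17 log units; within the scatter). That step leaves compound 2 and compound 3 level, so across this one pair the identity of the halogen does not register beyond the scatter. The comparison with the 4-bromophenyl compound gives the first gap in the series beyond the scatter, though a modest one: a 2.2-fold higher number from compound 1 to compound 3 (0.34 log units; beyond the scatter), a change that alters both the halogen and the ring substitution, so the two contributions cannot be separated, and no measurement on hand offers an explanation for either step.

Still open, as far as these compounds go, is whether that modest gap follows the identity of the halogen or where it sits on the ring. Also open, from the compounds shown here alone, is how this aromatic ring responds to groups other than halogens, such as a methoxy group, a nitrile or an unsubstituted phenyl, and whether the value holds with a longer chain between the shared core and the urea-type linker.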